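A few compounds are considered here, and "the series" means these few. Any claim that something is new, unique, unknown or untested is made for them only; others in the source may bear on it.

The series centres on a hydroxamic acid joined through a short chain to a sulfur-linked aromatic ring. Compound 1, `O=C(CCCCCSc1ccccc1)NO`, carries a saturated chain; in a functional assay on CCRF-CEM cells (Homo sapiens) for inhibition (a lower number here means a stronger inhibitor, a higher number a weaker inhibitor), compound 1 reaches only a limit of the assay, > 25000 nM, so no number is known for it. Compound 2, `O=C(/C=C/C=C/C[S+]([O-])c1ccc(Cl)cc1)NO`, has a diene chain and an oxidised sulfur bearing a chloro-substituted ring, and in this assay compound 2 gives "not determined" (no result reported). Compound 3, `O=C(/C=C/C=C/CSc1ccccc1)NO`, keeps the diene chain and the plain sulfur link, and in this assay compound 3 likewise gives "not determined" (no result reported).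

Compound 3 therefore stands without a number of its own: one further value in this assay is a limit, (the limit of > 25000 nM in this assay, at which 1 of the 3 values shown sits), and one further entry has no result. Compound 4, `O=C(/C=C/C=C/CSc1ccc(Cl)cc1)NO`, is compound 3 with chloro in place of hydrogen on an aromatic carbon. Going by the values given here, no measured pair mirrors this change, so no step size can be read from the data. He expects the change to make no difference beyond the usual scatter of this assay. For compound 4 he estimates 8000 nM, within a range from 1000 nM to 30000 nM.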

Compound 4, half-maximal inhibitory concentration: 1600 nM
Compound 4: the middle estimate sits 5.0-fold (0.70 log units) above what was measured, and the stated range covers the measured number.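

No step can be read between compound 3 and compound 4: compound 3 has no single number in this assay. The compounds shown leave open what chloro in place of hydrogen changes on the aromatic ring, and how the diene chain compares with the saturated chain.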